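Swapping the pyrazole for a dimethylaminophenyl on the core

This account rests on a few compounds, and the source may have more. Where it says the series, first, only, none or still open, it means among the compounds named here.

Compound 2 `Cn1nccc1-c1cnc2ncn(Cc3ccc4ncccc4c3)c2n1` is the weaker of the two compounds measured in a functional assay on NCI-H1993 cells (Homo sapiens) for inhibition, read by CCK-8 assay, with a stated time of 72 h; a lower number here means a stronger inhibitor, a higher number a weaker inhibitor; in this assay compound 2 gives 7910 nM, the highest of the two numbers. Compound 1 `Cc1c(C(C)n2cnc3ncc(-c4cn[nH]c4)nc32)ccc2ncccc12`, the nearest neighbour, gives 599 nM, a much lower number that lies beyond the scatter, though compound 1 differs from compound 2 in more than one place, so no single step can be read from that pair.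

Compound 3 `CN(C)c1cccc(-c2cnc3ncn(Cc4ccc5ncccc5c4)c3n2)c1` has not yet been measured in this assay. It differs from compound 2 in one place: 3-(dimethylamino)phenyl in place of 1-methyl-1H-pyrazol-5-yl on an aromatic carbon.

Going by the values given here, with no measured step of this kind to lean on, the author expects compound 3 to move only modestly, as a step of a 2.0-fold lower number from compound 2 to compound 3 (0.30 log units; within the scatter) toward a lower number that may not clear the scatter. The estimate for compound 3 in this assay is 4000 nM, within 800 nM to 20000 nM.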

Compound 3, half-maximal inhibitory concentration: > 10000 nM
Compound 3: no number, only a limit (the forecaster's own chance of this, stated with the estimate: 10%); middle value at least 2.5-fold (0.39 log units) from the limit.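

At this aromatic carbon, next to the ring nitrogen, the step to the 3-(dimethylamino)phenyl group brought no lower number in this assay: the change gives an at least 1.2-fold higher number from compound 2 to compound 3 (0.10 log units; that floor lies within the scatter). Compound 3 gives > 10000 nM, which is a limit of the assay and not a number. The floor of the step lies within the scatter, so the size of the change cannot be fixed because the reading stops at a limit: the limit of > 10000 nM in this assay, at which 1 of the 3 values shown sits.

The compounds shown leave open whether the carbon-only ring or the dimethylamino group goes with this result, which a plain phenyl on the same carbon would separate. They also leave open how other groups at this carbon, such as a morpholine or a carboxylic acid, would read in this assay.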